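Piperidin-1-yl in place of pyrrolidin-1-yl on compound 2

This account rests on a few compounds, and the source may have more. Where it says the series, first, only, none or still open, it means among the compounds named here.

In a functional assay on HCT-116 cells (Homo sapiens) for cytotoxicity, read by MTT assay, with a stated time of 72 h (a higher number here means a weaker inhibitor, a lower number a stronger inhibitor), compound 2 (`O=C1c2c[n+]([O-])c3ccccc3c2C(=O)c2c1c1ccccc1n2CCN1CCCC1`) gives 270 nM as its reading. Compound 3 (`CC1(C)OC[C@@H](Cn2cc(Cn3c4c(c5ccccc53)C(=O)c3c[n+]([O-])c5ccccc5c3C4=O)nn2)O1`) gives 340 nM and lies within the scatter of that reading. Compound 1 (`CC1(C)OCC(Cn2cc(Cn3c4c(c5ccccc53)C(=O)c3c[n+]([O-])c5ccccc5c3C4=O)nn2)O1`) gives 70 nM and so sits lower than compound 2 by more than the scatter.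

Compound 4 (`O=C1c2c[n+]([O-])c3ccccc3c2C(=O)c2c1c1ccccc1n2CCN1CCCCC1`) is still unmeasured and departs from compound 2 in one place: piperidin-1-yl in place of pyrrolidin-1-yl on a saturated chain carbon, two bonds along the chain from an aromatic nitrogen on a saturated chain carbon, two bonds along the chain from an aromatic nitrogen.

Among the compounds with values here, the only measured step, a 4.9-fold higher number from compound 1 to compound 3 (0.69 log units; beyond the scatter) and modest in size, goes with the fact that one of compounds 1 and 3 is drawn with a defined configuration and the other without, at the place where they differ and concerns a stereocentre at a saturated ring carbon. Within the data shown here, it does not bear directly on this exchange, and no measured step covers pyrrolidin-1-yl against piperidin-1-yl.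

With compound 2 at 270 nM as the sole anchor, no step beyond the scatter is expected in this assay and no direction is favoured. The expected step is a 1.1-fold lower number from compound 2 to compound 4 (0.03 log units; within the scatter) and it stays within the scatter. For compound 4 the estimate is 250 nM with an expected range from 90 nM to 700 nM as the working figures.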

Compound 4, half-maximal inhibitory concentration: 780 nM
Compound 4: the middle estimate sits 3.1-fold (0.49 log units) below what was measured; measured number outside the range, above it.
By their numbers in this assay, from the lowest: compound 1; then compounds 2 and 3 (each within the scatter of the next); then compound 4.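

In this assay, within the data shown here, the exchange of pyrrolidin-1-yl for piperidin-1-yl on a saturated chain carbon, two bonds along the chain from an aromatic nitrogen, gives a 2.9-fold higher number from compound 2 to compound 4 (0.46 log units; beyond the scatter) and so registers in the reading, which the earlier compounds could not show because they held only one such ring at this place. The six-membered ring goes with the higher number even though both groups carry the same hydrogen-bond donor and acceptor counts, but this rests on one pair and is not a trend. No available observation bears on why this exchange moves the reading.

The compounds shown leave open whether a further change in ring at this place, such as azepan-1-yl or morpholin-4-yl, would read nearer to compound 2 at 270 nM or to compound 4 at 780 nM in this assay. They also leave open how an open-chain amine such as dimethylamino, or a longer chain such as 3-(pyrrolidin-1-yl)propyl in place of 2-(pyrrolidin-1-yl)ethyl, would read on the same core.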